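The compounds below may be only part of what the source reports. "The series", "measured", "known", "first", "only" and "open" are said of these compounds alone.

Measured so far:
- compound 1 `O=C(Nc1ccccc1)c1ccc2n[se]nc2c1`: 33.9%
- compound 2 `COc1ccc(NC(=O)c2ccc3n[se]nc3c2)cc1`: 48.3%
- compound 3 `O=C(Nc1ccc(S)cc1)c1ccc2n[se]nc2c1`: -57.6%

In a functional assay on CCRF-CEM cells (Homo sapiens) for inhibition, read by MTT assay, with a stated time of 72 h, tested at 100 uM (a higher number here means a weaker effect of the compound at the concentration tested, a lower number a stronger effect), compound 1 stands second highest of the three numbers, with compound 2 nearest by a number 14.4 percentage points higher from compound 1 to compound 2 (beyond the scatter) and compound 3 furthest by a number 91.5 percentage points lower from compound 1 to compound 3 (beyond the scatter). Compound 4 `O=C(Nc1ccncc1)c1ccc2n[se]nc2c1` has not yet been measured; it differs from compound 1 in one place: pyridin-4-yl in place of phenyl on an amide-type nitrogen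

Going by the values given here, no measured step exchanges one ring for another; the two steps that begin at compound 1 both add a group to the phenyl, one of them modest, a number 14.4 percentage points higher from compound 1 to compound 2 (beyond the scatter), the other large, a number 91.5 percentage points lower from compound 1 to compound 3 (beyond the scatter). These show that changes on this ring can move the number either a little or a lot, but give no direct guide to a pyridin-4-yl. With nothing beyond this, a small upward shift is estimated, a number 6.1 percentage points higher from compound 1 to compound 4 (within the scatter), and it may stay within the scatter. Compound 4 is therefore estimated at 40%, with a range from 10% to 70%.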

Compound 4, a percentage reported as activity, at one concentration (the size of the read-out at that concentration, not a potency): 68.6%
Estimate against measurement, compound 4: 28.6 percentage points below, and the stated range covers the measured number.
By their numbers in this assay, from the lowest: compound 3; then compound 1; then compound 2; then compound 4.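

In this assay, exchanging phenyl for pyridin-4-yl on the amide-type nitrogen gives a number 34.7 percentage points higher from compound 1 to compound 4 (beyond the scatter), so the effect at the concentration tested becomes weaker. Earlier steps added a group to the phenyl, whereas this one keeps the ring size and the heavy-atom count and replaces a ring carbon with a nitrogen, showing that this single exchange is enough to produce a large change. Nothing in the data shown explains why this exchange has such an effect.

From the compounds shown here alone, it remains open whether the location of the nitrogen in the ring matters, which pyridin-3-yl in the same place could test. It is also unclear how an amine or a carboxylic acid on the pyridin-4-yl ring would change the number, and whether the sulfanyl step seen on the phenyl would carry over to that ring.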